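A few compounds are considered here, and "the series" means these few. Any claim that something is new, unique, unknown or untested is made for them only; others in the source may bear on it.

Among the compounds with values here, compound 2 `O=C(Nc1cccnc1)N1CCc2ccccc2[C@H]1c1ccc(C(F)(F)F)cc1` gives 22 nM in an assay on CHO cells for antagonist activity at transient receptor potential cation channel subfamily M member 8 (Rattus norvegicus), read by luminescence and calcium flux, with a stated time of 2.5 min (on this read-out higher numbers stand for weaker inhibition and lower numbers for stronger inhibition), which is the lowest of the two numbers measured so far. Within the data shown here, its nearest neighbour is compound 1 `N#Cc1ccccc1NC(=O)N1CCc2ccccc2[C@H]1c1ccc(C(F)(F)F)cc1`, which in this assay gives 104 nM; the difference between them is a 4.7-fold lower number from compound 1 to compound 2 (0.67 log units; beyond the scatter), the only measured step in this set. Compound 3 `O=C(Nc1ccncc1)N1CCc2ccccc2[C@H]1c1ccc(C(F)(F)F)cc1` has not yet been measured. It differs from compound 2 only in how the same atoms are joined: pyridin-4-yl in place of pyridin-3-yl on an amide-type nitrogen. Among the measured compounds shown here, the single measured step concerns a different exchange on the same amide-type nitrogen, so it says little about moving the nitrogen within the pyridyl ring, and no other comparison is available. With nothing pointing in either direction, compound 3 is expected to stay close to compound 2, with an estimated step of a 1.4-fold higher number from compound 2 to compound 3 (0.13 log units; within the scatter) that lies within the scatter. The estimate for compound 3 in this assay is therefore 30 nM, ranging from 10 nM to 90 nM.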

Compound 3, half-maximal inhibitory concentration: 306 nM
Compound 3: middle estimate off by 10-fold (1.01 log units), on the low side; measured number outside the range, above it.
By their numbers in this assay, from the lowest: compound 2; then compound 1; then compound 3.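

In this assay, moving only the nitrogen within the ring, with the atom counts unchanged, has a large effect at this position: pyridin-4-yl in place of pyridin-3-yl gives a 14-fold higher number from compound 2 to compound 3 (1.14 log units; beyond the scatter) on the amide-type nitrogen. The comparison with the earlier group shows a 2.9-fold higher number from compound 1 to compound 3 (0.47 log units; beyond the scatter), so replacing 2-cyanophenyl with a pyridine ring can lower the number, as in compound 2, or raise it, as in compound 3, depending on where the ring nitrogen sits. Nothing measured here explains this gap.

Still open, on these data alone, is whether pyridin-2-yl, the remaining placement of that nitrogen, would lie nearer compound 2 or compound 3. A plain phenyl ring or a pyrimidinyl ring on the same amide-type nitrogen would also help show how far this sensitivity extends.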